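Difluoromethyl Enters the Fused Ring of Compound 3

This account rests on a few compounds, and the source may have more. Where it says the series, first, only, none or still open, it means among the compounds named here.

Of the compounds shown here, three built on one shared core have been measured in a physicochemical assay for lipophilicity, using the shake flask method; on this read-out lower numbers stand for lower lipophilicity and higher numbers for higher lipophilicity. Compound 1 `C[C@H](Oc1ccnc(C2CC2)n1)c1c(Cl)ccc(F)c1Cl` gives 4.2. Compound 2 `C[C@H](Oc1ccc(NC(=O)CC(=O)O)c(C2CC2)c1)c1c(Cl)ccc(F)c1Cl` gives 1.9. Compound 3 `C[C@H](Oc1ccc2ncc(/C=C/C(=O)O)cc2c1)c1c(Cl)ccc(F)c1Cl` gives 2.5, the second highest of the three numbers; its nearest neighbour is compound 2, lower by a gap beyond the scatter, and the furthest is compound 1, higher by a gap beyond the scatter.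

Compound 4 `C[C@H](Oc1ccc2ncc(/C=C/C(=O)O)c(C(F)F)c2c1)c1c(Cl)ccc(F)c1Cl` differs from compound 3 in one place: difluoromethyl in place of hydrogen on an aromatic carbon. Within the data shown here, no pair of measured compounds shows this change, so its size is not known from the data. The step of a number 0.40 log units higher from compound 3 to compound 4 (beyond the scatter) is expected to be modest and upward in this assay. Compound 4 is accordingly estimated at 2.9, with a range from 2.4 to 3.5.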

Compound 4, distribution coefficient: 3.1
The estimate for compound 4 lay 0.20 log units below the measured number; low and high end bracket the measured number.
By their numbers in this assay, from the lowest: compound 2; then compound 3; then compound 4; then compound 1.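

In this assay, among these compounds, difluoromethyl in place of hydrogen on an aromatic carbon gives a number 0.60 log units higher from compound 3 to compound 4 (beyond the scatter), the first change in one place that can be read. It shows that the read-out responds to substitution at this carbon, ortho to a 2-carboxyethenyl group and opposite the ring nitrogen. No measured evidence on the cause of this step is at hand.

From the compounds shown here alone, whether methyl or trifluoromethyl on this same carbon would give a similar step remains open. So does whether difluoromethyl would give it elsewhere on this ring.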